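The compounds below may be only part of what the source reports. "The series", "measured", "known", "first", "only" and "open" are said of these compounds alone.

Compound 3 `Cn1c(-c2ccccc2)nc2c(NC3CCCCC3)ncnc21` is one of three measured members of a shared core. In a functional assay on CHO cells for antagonist activity at adenosine receptor A2b (Homo sapiens), read by 33P incorporation, with a stated time of 20 min (on this read-out lower numbers stand for stronger inhibition and higher numbers for weaker inhibition), compound 3 gives > 30000 nM, which is a limit of the assay and not a number. Compound 2 `CCn1c(-c2ccccc2)nc2c(NC3CCCCC3)ncnc21` carries ethyl where compound 3 carries methyl. In this assay, for the measured compounds named here, compound 2 gives 9020 nM, so that the step of an at least 3.3-fold higher number from compound 2 to compound 3 (0.52 log units; beyond the scatter) is the only measured change between two members, and it concerns a different place than the one now in question. Compound 1 `Cn1c(-c2ccc(F)cc2)nc2c(NC3CCCC3)ncnc21` gives > 30000 nM in this assay, again a limit. This limit is where two of the three values sit (the limit of > 30000 nM in this assay, at which 2 of the 3 values shown sit).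

Compound 4 `Cn1c(-c2ccccc2)nc2c(NC3CCOC3)ncnc21` differs from compound 3 by oxolan-3-yl in place of cyclohexyl on a nitrogen on an aromatic ring. Going by the values given here, no measured step touches this change, so the expectation rests on compound 3 alone, which stands at a limit. Compound 4 is therefore estimated at 30000 nM, between 8000 nM and 100000 nM, an expected step of a number no higher from compound 3 to compound 4 (the limit leaves the size open), most likely again returned as a limit.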

Compound 4, inhibition constant: 13300 nM
Compound 4: middle estimate off by 2.3-fold (0.35 log units), on the high side, within the range that was stated.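

In this assay, oxolan-3-yl in place of cyclohexyl on a nitrogen on an aromatic ring gives an at least 2.2-fold lower number from compound 3 to compound 4 (0.35 log units; beyond the scatter). For the compounds shown here, this is the first measured step at this place, and it shows that the group on this nitrogen can bring a member of the series to a measured value, here with a five-membered ring holding one oxygen instead of a six-membered ring of carbon only. The full size of the step cannot be read, because compound 3 stands at a limit: the limit of > 30000 nM in this assay, at which 2 of the 4 values shown sit.

The compounds shown do not separate the ring oxygen from the ring size, a question that oxan-4-yl on this nitrogen would address. They also leave open how an open-chain ether such as 2-methoxyethyl, or an amine such as piperidin-4-yl, would read here.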